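The source may report more compounds than this note shows. Statements on the series, on what has been measured and on what is new or still open speak of the compounds shown alone.

Working notes on the series. Compound 1 `O=[N+]([O-])c1ccc2[nH]c(-c3nc(-c4ccccc4)no3)cc2c1` in a functional assay on MIA PaCa-2 cells (Homo sapiens) for antiproliferative activity, read by WST assay, with a stated time of 72 h (a lower number here means a stronger inhibitor, a higher number a weaker inhibitor), gives > 50000 nM, which is a limit of the assay and not a number. Compound 2 `Fc1ccc2[nH]c(-c3nc(-c4ccc(Cl)cc4)no3)cc2c1` in this assay gives > 50000 nM, again a limit rather than a number. Compound 2 thus stands at the limit of > 50000 nM in this assay, at which 2 of the 2 values shown sit, and no ordering between compound 1 and compound 2 can be read from two limits. Compound 3 `O=[N+]([O-])c1ccc2[nH]c(-c3nc(-c4ccc(Cl)cc4)no3)cc2c1` is not yet measured. It differs from compound 2 by nitro in place of fluoro on an aromatic carbon, in words nitro in place of fluoro on an aromatic carbon. Within the data shown here, no measured step between compounds covers this change. Compound 1 also carries a nitro group and gives > 50000 nM, a limit. No step beyond the scatter is expected in this assay; the expected step from compound 2 to compound 3 is a number no higher from compound 2 to compound 3 (the limit leaves the size open). Compound 3 is expected at 50000 nM, with a range from 20000 nM to 200000 nM, most likely reported once more as a limit.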

Compound 3, half-maximal inhibitory concentration: 17600 nM
Compound 3: the middle estimate sits 2.8-fold (0.45 log units) above what was measured, outside the stated range (below it).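

In this assay, with the chloro group held constant, nitro in place of fluoro on this aromatic carbon gives an at least 2.8-fold lower number from compound 2 to compound 3 (0.45 log units; beyond the scatter), so the group at this position can change the read-out. With the nitro group held constant, chloro in place of hydrogen gives an at least 2.8-fold lower number from compound 1 to compound 3 (0.45 log units; beyond the scatter), so nitro alone does not bring a compound off the limit, and only compound 3, which carries both groups, has a number. The other compounds remain limits, not numbers: the limit of > 50000 nM in this assay, at which 2 of the 3 values shown sit.

Going by these compounds, both steps start from limits, so their full size stays open. Also open, on these data alone, is how an amine or a nitrile on the same aromatic carbon, or a methoxy group in place of chloro, would compare with compound 3.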